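Pyrazole versus thiazole on the fused core

The source may hold more compounds than are shown below. What is called first, only, known or untested is meant among the compounds shown, and "the series" means these compounds.

Compound 1 `Cc1n[nH]cc1-c1cccc2c1CCC2c1ncc[nH]1` in a functional assay on CHO cells for agonist activity at Alpha-1B adrenergic receptor (Homo sapiens), read by FLIPR and calcium flux (a higher number here means that more compound is needed for the effect, a lower number that less compound is needed), gives 902 nM
Compound 2 `c1cncc(-c2cccc3c2CCC3c2ncc[nH]2)c1` in this assay gives > 10000 nM
Compound 3 `c1cc(-c2nccs2)c2c(c1)C(c1ncc[nH]1)CC2` in this assay gives > 10000 nM

The values of compound 2 and compound 3 are limits of the assay and not numbers; both sit at the limit of > 10000 nM in this assay, at which 2 of the 3 values shown sit. Compound 3 therefore stands only as a limit, among the values shown, with no number of its own, and its distance from compound 2 is a step the two limits leave unreadable a step that the two limits leave unreadable from compound 2 to compound 3.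

Compound 4 `c1cc(-c2cn[nH]c2)c2c(c1)C(c1ncc[nH]1)CC2` differs from compound 3 in one place: 1H-pyrazol-4-yl in place of 1,3-thiazol-2-yl on an aromatic carbon. Compound 4 thus carries the pyrazole of compound 1 without its methyl.

Among the measured compounds shown here, two measured steps bear on this change. From compound 1 to compound 3 the number rose an at least 11-fold higher number from compound 1 to compound 3 (1.04 log units; beyond the scatter), and from compound 1 to compound 2 it rose an at least 11-fold higher number from compound 1 to compound 2 (1.04 log units; beyond the scatter). Running the first of these in reverse, the pyrazole of compound 4 is expected to bring the number down, out of the limit and toward compound 1, though the missing methyl leaves the size uncertain.

The estimate for compound 4 is 2000 nM, in the range 700 nM to 8000 nM, which means an expected step of an at least 5.0-fold lower number from compound 3 to compound 4 (0.69 log units; beyond the scatter).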

Compound 4, half-maximal effective concentration: > 10000 nM
Compound 4: a limit, no number (the forecaster's own chance of this, stated with the estimate: 25%); at least 5.0-fold (0.69 log units) between middle value and limit.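

Compound 4 gives > 10000 nM in this assay, which is a limit and not a number. The pyrazole ring without its methyl therefore does not restore a measurable value, and hydrogen in place of methyl alone gives an at least 11-fold higher number from compound 1 to compound 4 (1.04 log units; beyond the scatter), so among the compounds shown, only the methylated pyrazole of compound 1 gives a number. Compound 2, compound 3 and compound 4 cannot be ranked, and the steps among them cannot be read, because all three share the same limit: the limit of > 10000 nM in this assay, at which 3 of the 4 values shown sit.

As far as these compounds go, what remains open is how the number would respond to an ethyl group or a chlorine atom in place of the methyl of compound 1. Also open, from the compounds shown here alone, is whether adding a methyl group to the thiazole of compound 3 or the pyridine of compound 2 would bring either compound below the limit.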